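Swapping the Sulfur-Linked Side Chain for a Methoxy Group

The source may report more compounds than this note shows. Statements on the series, on what has been measured and on what is new or still open speak of the compounds shown alone.

Measured so far:
Compound 1 `CC(C)c1n[nH]c2c(NCc3ccc(-c4ccccn4)cc3)nc(SCC3CNC(=O)O3)nc12`: 80 nM
Compound 2 `CC(C)c1n[nH]c2c(NCc3ccc(-c4ccccn4)cc3)nc(SCCn3ccnc3)nc12`: 155 nM

In a functional assay on HT cells (Homo sapiens) for antiproliferative activity, read by fluorescence, with a stated time of 72 h (on this read-out higher numbers stand for weaker inhibition of growth and lower numbers for stronger inhibition of growth), compound 1 gives 80 nM and compound 2 gives 155 nM. Compound 1 has the smaller of the two numbers, but the gap to compound 2 is within the scatter, so the two cannot be told apart. Within the data shown here, the one step known so far is a 1.9-fold higher number from compound 1 to compound 2 (0.29 log units; within the scatter), a change at the same place as the one now considered.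

Compound 3 `COCSc1nc(NCc2ccc(-c3ccccn3)cc2)c2[nH]nc(C(C)C)c2n1` differs from compound 1 by methoxy in place of 2-oxo-1,3-oxazolidin-5-yl on a saturated chain carbon bound to a sulfur. Among the measured compounds shown here, the only step that bears on it, a 1.9-fold higher number from compound 1 to compound 2 (0.29 log units; within the scatter), stayed within the scatter, which suggests this position tolerates replacement of the 2-oxo-1,3-oxazolidin-5-yl without a large shift. A methoxy is a smaller group than either alternative, so a modest rise in the number, or none beyond the scatter, is expected: a 1.9-fold higher number from compound 1 to compound 3 (0.27 log units; within the scatter). Compound 3 is estimated at 150 nM, within a range of 60 nM to 400 nM.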

Compound 3, concentration for 50% growth inhibition: 340 nM
Compound 3: middle estimate off by 2.3-fold (0.36 log units), on the low side, within the range that was stated.
By their numbers in this assay, from the lowest: compounds 1 and 2 (each within the scatter of the next); then compound 3.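

In this assay, this place on a saturated chain carbon bound to a sulfur turns out not to accept every replacement, as methoxy gives a 4.3-fold higher number from compound 1 to compound 3 (0.63 log units; beyond the scatter) and a 2.2-fold higher number from compound 2 to compound 3 (0.34 log units; beyond the scatter). Both steps are modest, but unlike the swap between the two ring-bearing groups, they lie beyond the scatter, so the tolerance seen with compound 1 and compound 2 does not extend to this group, which has no ring and only 2 heavy atoms. No supporting measurement is available to explain this shift.

Because methoxy differs from the earlier groups in both size and the absence of a ring, the compounds shown cannot separate these two changes. A ringless longer chain such as a butyl chain, or a small ring such as cyclopropyl, at this place would help tell them apart, while an amine or a carboxylic acid remains an open question.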